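The source may report more compounds than this note shows. Statements on the series, on what has been measured and on what is new or still open speak of the compounds shown alone.

Measured so far in a functional assay on DU-145 cells (Homo sapiens) for inhibition, read by MTT assay, with a stated time of 48 h (a lower number here means a stronger inhibitor, a higher number a weaker inhibitor), for the series:
- compound 1 `CCc1ccc(-c2nc3ccccn3c2Sc2ccccc2)cc1` gives 84500 nM
- compound 2 `c1ccc(Sc2c(-c3ccccc3)nc3ccc(-c4ccccc4)cn23)cc1` gives 71700 nM
- compound 3 `Cc1ccc2nc(-c3ccc(Cl)cc3)c(Sc3ccccc3)n2c1` gives 95100 nM

Compound 1 lies within the scatter of both compound 2 and compound 3, so no order can be read among it and these two neighbours. The next compound to be tested is compound 4 `Clc1ccc(-c2nc3ccccn3c2Sc2ccccc2)cc1`, which differs from compound 1 as follows: chloro in place of ethyl on an aromatic carbon. In short, the 4-ethylphenyl group of compound 1 gives way to a 4-chlorophenyl group in compound 4.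

For the measured compounds named here, no pair of measured compounds isolates this change. The nearest evidence is compound 3, which also carries a 4-chlorophenyl group but differs elsewhere on the core and gives 95100 nM within the scatter of compound 1. No shift beyond the scatter is therefore expected in this assay for this change. The step of a 1.0-fold higher number from compound 1 to compound 4 (0.00 log units; within the scatter) is expected to stay within the scatter. For compound 4 the estimate is 85000 nM with an expected range from 50000 nM to 140000 nM in this read-out.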

Compound 4, half-maximal inhibitory concentration: 30700 nM
Compound 4: middle estimate off by 2.8-fold (0.44 log units), on the high side, and the stated range ends above it.
By their numbers in this assay, from the lowest: compound 4; then compounds 2, 1 and 3 (each within the scatter of the next).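

In this assay, for the compounds shown here, the change from 4-ethylphenyl to 4-chlorophenyl gives a 2.8-fold lower number from compound 1 to compound 4 (0.44 log units; beyond the scatter) and is the first step beyond the scatter, so the group on this aromatic carbon can move the number. Hydrogen in place of methyl on an aromatic carbon, with the 4-chlorophenyl group kept, gives a 3.1-fold lower number from compound 3 to compound 4 (0.49 log units; beyond the scatter) and shows that this group does not set the low number alone: the methyl-bearing compound 3 has it too and stays high. Nothing at hand bears on the reason for either step.

From the compounds shown here alone, only ethyl and chloro have been compared at this place, so it remains open how a methoxy group, an amine, a carboxylic acid or a longer chain would read there. Going by these compounds, whether the methyl step holds with groups other than 4-chlorophenyl also remains open.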